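The compounds below may be only part of what the source reports. "The series", "measured", "known", "first", "only" and "open" are said of these compounds alone.

Compound 2 (`Cn1cccc1-c1ccccc1NCC1=NCCN1`) gives 251 nM in an in vitro functional assay on cells (Fibroblast) for agonist activity at Alpha-1D adrenergic receptor (Homo sapiens) (a lower number here means that less compound is needed, a higher number that more compound is needed for the effect), and stands highest of the two numbers shown in the series. Compound 1 (`Cn1ccc(-c2ccccc2NCC2=NCCN2)n1`) gives 15.9 nM, and the step of a 16-fold higher number from compound 1 to compound 2 (1.20 log units; beyond the scatter) is a change of the five-membered ring on the shared core. Compound 3 (`CCn1cccc1-c1ccccc1NCC1=NCCN1`) gives only a limit, < 100000 nM. Because of the limit of < 100000 nM in this assay, at which 1 of the 3 values shown sits, the step that the limit leaves unreadable from compound 2 to compound 3 cannot be read.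

Compound 4 (`Cc1ccc(-c2ccccc2NCC2=NCCN2)n1C`) differs from compound 2 by methyl in place of hydrogen on an aromatic carbon. Neither measured step bears directly on this change. The step from compound 1 to compound 2 swaps the whole ring rather than a single substituent, and the step from compound 2 to compound 3 lengthens the group on the ring nitrogen and is unreadable. What the series does show is that changes around the five-membered ring move this assay by large amounts, so a wide range is kept. Compound 4 is expected to sit near compound 2, with a step of a 1.6-fold higher number from compound 2 to compound 4 (0.20 log units; within the scatter), no larger than the scatter in the middle case. For compound 4 the estimate is 400 nM, with a range from 80 nM to 3000 nM.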

Compound 4, half-maximal effective concentration: < 100000 nM
Compound 4: a limit, no number; the forecaster's own chance of this, stated with the estimate: 15%; the middle value lies beyond the limit too.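

Compound 4 gives only a limit (< 100000 nM) in this assay and no new step can be read from compound 2 to compound 4, because of this: the limit of < 100000 nM in this assay, at which 2 of the 4 values shown sit. Still open, going by these compounds, is what methyl in place of hydrogen on an aromatic carbon does to the number of compound 2, and how far compound 3 and compound 4 lie from compound 2.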